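The compounds below may be only part of what the source reports. "The series", "measured", "known", "first", "only" and "open" are said of these compounds alone.

Working notes on the series.

Compound 3 `COc1ccc(C2=NN(C(=O)c3ccc(Cl)nc3)C(c3ccc(OCc4ccccc4)cc3)C2)cc1` gives 10600 nM in a functional assay on WM 266-4 cells (Homo sapiens) for antiproliferative activity, read by MTT assay, with a stated time of 24 h; a lower number here means a stronger inhibitor of growth, a higher number a weaker inhibitor of growth. Among the measured compounds shown here, compound 1 `COc1ccc(C2=NN(C(=O)c3ccc(C)nc3Cl)C(c3ccc(Br)cc3)C2)cc1` gives 8470 nM in this assay, and compound 2 `COc1ccc(C2=NN(C(=O)c3cncc(Br)c3)C(c3ccc(OCc4ccccc4)cc3)C2)cc1` gives 6240 nM; compound 3 thus stands with both of them within the scatter of a single number, and no compound of the three can be set apart from the others.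

For the measured compounds named here, the only step measured on the carbonyl-bound group, a 1.7-fold higher number from compound 2 to compound 3 (0.23 log units; within the scatter), changed nothing beyond the scatter. The step to compound 4 `COc1ccc(C2=NN(C(=O)c3ccc(C)nc3Cl)C(c3ccc(OCc4ccccc4)cc3)C2)cc1` is of the same kind at the same place: 2-chloro-6-methylpyridin-3-yl in place of 6-chloropyridin-3-yl on a carbonyl carbon. Compound 1 already carries the entering group on its carbonyl, on a different core, and its value of 8470 nM is indistinguishable from compound 3; this is not a measured step, only what two values show.

Taken together, no step beyond the scatter is expected in this assay. Compound 4 is estimated at 9000 nM, between 4000 nM and 20000 nM, which means an expected step of a 1.2-fold lower number from compound 3 to compound 4 (0.07 log units; within the scatter).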

Compound 4, concentration for 50% growth inhibition: 10500 nM
Compound 4: middle estimate off by 1.2-fold (0.07 log units), on the low side; low and high end bracket the measured number.
By their numbers in this assay, from the lowest: compounds 2, 1, 4 and 3 (each within the scatter of the next).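

On a carbonyl carbon, 2-chloro-6-methylpyridin-3-yl in place of 6-chloropyridin-3-yl gives a 1.0-fold lower number from compound 3 to compound 4 (0.00 log units; within the scatter) in this assay, and in place of 5-bromopyridin-3-yl it gives a 1.7-fold higher number from compound 2 to compound 4 (0.23 log units; within the scatter) on the same shared core, so all three pyridinyl groups shown at this place stay within the scatter of one another. The first step away from the carbonyl-bound group, benzyloxy in place of bromo on an aromatic carbon, gives a 1.2-fold higher number from compound 1 to compound 4 (0.09 log units; within the scatter) with 2-chloro-6-methylpyridin-3-yl held fixed, so this second place shows no step beyond the scatter either. No measurement at hand bears on these results.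

Every carbonyl-bound group shown is a halogen-bearing pyridinyl, so it remains open whether a pyridinyl carrying an amine or a carboxylic acid, or an unsubstituted phenyl, would move the number beyond the scatter. On the aromatic carbon only bromo and benzyloxy appear, which leaves open a hydroxy group or a longer alkoxy chain.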